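A few compounds are considered here, and "the series" means these few. Any claim that something is new, unique, unknown or untested is made for them only; others in the source may bear on it.

Measured compounds:
Compound 1 `CCC(C)(C)Cc1c[nH]c(CCc2ccc(-c3ccncc3)cc2)n1` — 95 nM
Compound 2 `CCC(C)(C)Cc1c[nH]c(CCc2ccc(-c3cccc(C#N)n3)cc2)n1` — 95 nM
Compound 3 `CCC(C)(C)Cc1c[nH]c(CCc2ccc(-c3csnn3)cc2)n1` — 104 nM

In a functional assay on HEK293 cells for agonist activity at Bombesin receptor subtype-3 (Homo sapiens), read by luminescence and calcium flux, with a stated time of 10 min (a higher number here means that more compound is needed for the effect, a lower number that less compound is needed), compound 2 gives 95 nM, level with compound 1 at the digits shown, and together with compound 1 it stands at the lowest of the three numbers; its nearest neighbour is compound 1, no change at the digits printed from compound 1 to compound 2 (within the scatter), and its furthest is compound 3, a 1.1-fold higher number from compound 2 to compound 3 (0.04 log units; within the scatter). Compound 4 `CCC(C)(C)Cc1c[nH]c(CCc2ccc(-c3cccnc3C(=O)O)cc2)n1` has not yet been measured in this assay. It differs from compound 2 in one place: 2-carboxypyridin-3-yl in place of 6-cyanopyridin-2-yl on an aromatic carbon.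

Within the data shown here, the steps that bear on this change are those that swap the ring at the same position: no change at the digits printed from compound 1 to compound 2 (within the scatter), a 1.1-fold higher number from compound 1 to compound 3 (0.04 log units; within the scatter) and a 1.1-fold higher number from compound 2 to compound 3 (0.04 log units; within the scatter). Each of them stays within the scatter, so across the three measured compounds the ring attached there could be varied without any step beyond the scatter. Among the measured compounds shown here, none of them, however, brings in a hydrogen-bond donor or a carboxylic acid, so no measured step speaks directly to the group that enters in compound 4. The step of a 2.6-fold higher number from compound 2 to compound 4 (0.42 log units; beyond the scatter) is therefore expected to be modest, with a wider range than the measured steps would alone suggest. Compound 4 is estimated at 250 nM, within 70 nM to 1500 nM.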

Compound 4, half-maximal effective concentration: 95 nM
The estimate for compound 4 lay 2.6-fold (0.42 log units) above the measured number, within the range that was stated.
By their numbers in this assay, from the lowest: compounds 1, 2, 4 and 3 (each within the scatter of the next).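

In this assay the entry of 2-carboxypyridin-3-yl on this aromatic carbon gives no change at the digits printed from compound 2 to compound 4 (within the scatter) and no change at the digits printed from compound 1 to compound 4 (within the scatter) as well as a 1.1-fold lower number from compound 3 to compound 4 (0.04 log units; within the scatter) against the thiadiazole ring. The earlier steps shown here only exchanged rings that carry no hydrogen-bond donor, whereas compound 4 brings in a carboxylic acid with such a donor and still stands within the scatter of all three other compounds. Across these four compounds, then, the group para to the large group has been varied without a single step beyond the scatter, and no compound goes against that pattern, though it reaches no further than these four.

Going by these compounds, whether an amine, an amide or a longer chain in place of the carboxylic acid on the pyridine ring would also stay within the scatter remains open, as does the effect of a saturated ring at this place. No supporting evidence is available to explain why the numbers of these compounds lie so close together.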